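Working notes: isobutyl to cyclobutylmethyl

The source may report more compounds than this note shows. Statements on the series, on what has been measured and on what is new or still open speak of the compounds shown alone.

Measured in a physicochemical assay for lipophilicity; on this read-out lower numbers stand for lower lipophilicity and higher numbers for higher lipophilicity:
- compound 1 `CC(C)CN1C(=O)CN(Cc2ccc(-c3ccc(F)c(CN4CCCC(C)C4)n3)cc2)C1=O` gives 3.9
- compound 2 `CC(C)CN1C(=O)CN(Cc2ccc(-c3ccc(F)c(CN4CCCCC4)n3)cc2)C1=O` gives 3.4
- compound 3 `O=C1CN(Cc2ccc(-c3cccc(CN4CCCCC4)n3)cc2)C(=O)N1C1CC1` gives 1.6

Compound 2 stands second highest of the three, with compound 1 above it and compound 3 lowest, both gaps beyond the scatter. The next structure is compound 4 `O=C1CN(Cc2ccc(-c3ccc(F)c(CN4CCCCC4)n3)cc2)C(=O)N1CC1CCC1`. The change is cyclobutyl in place of isopropyl on a saturated chain carbon bound to an amide-type nitrogen in a ring, or, cut one bond further out, isobutyl to cyclobutylmethyl.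

Among the compounds with values here, only one measured step offers a guide, and it lies at another place: a number 0.50 log units lower from compound 1 to compound 2 (beyond the scatter), with hydrogen in place of methyl on a saturated ring carbon. Read in reverse, that step is a modest rise on gaining a carbon, and compound 4 also gains one, so a rise of similar or smaller size is expected in this assay. The expected change is a number 0.30 log units higher from compound 2 to compound 4 (within the scatter). For compound 4 the estimated value is 3.7, with an expected range of 3.3 to 4.1.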

Compound 4, distribution coefficient: 3.5
Compound 4: middle estimate off by 0.20 log units, on the high side, and the stated range covers the measured number.
By their numbers in this assay, from the lowest: compound 3; then compounds 2 and 4 (each within the scatter of the next); then compound 1.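

In this assay, isobutyl to cyclobutylmethyl on a saturated chain carbon bound to an amide-type nitrogen in a ring gives a number 0.10 log units higher from compound 2 to compound 4 (within the scatter), so compound 2 and compound 4 cannot be told apart at this position. The step at the other place, a number 0.50 log units lower from compound 1 to compound 2 (beyond the scatter), lies beyond the scatter, so in these two pairs the gain of one carbon does not bring a step of the same size at both places. Nothing available accounts for this difference between the two steps.

Still open, from the compounds shown here alone, is how the read-out responds at this position to a longer chain, or to a hydroxyl or an amine on the chain. Also open, going by these compounds, is whether the swap to cyclobutylmethyl gives a similar step with the methyl on the saturated ring of compound 1 in place.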